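Removing the butyl group from compound 3

A few compounds are considered here, and "the series" means these few. Any claim that something is new, unique, unknown or untested is made for them only; others in the source may bear on it.

Measured so far in a functional assay on MCF7 cells (Homo sapiens) for antiproliferative activity, read by sulforhodamine B assay, with a stated time of 48 h; a higher number here means a weaker inhibitor, a lower number a stronger inhibitor:
- compound 1 `O=C1NCCN1c1ccc(S(=O)(=O)Nc2ccc3[nH]ccc3c2)cc1` gives 170 nM
- compound 2 `O=C1NCCN1c1ccc(S(=O)(=O)Nc2ccc(F)cc2)cc1` gives 690 nM
- compound 3 `CCCCc1ccc(NS(=O)(=O)c2ccc(N3CCNC3=O)cc2)cc1` gives 770 nM

Compound 3 and compound 2 lie within the scatter of each other, and compound 1 stands clear of compound 3 with a lower number. The unmeasured compound 4 `O=C1NCCN1c1ccc(S(=O)(=O)Nc2ccccc2)cc1` follows from compound 3 by one change, (hydrogen in place of butyl on an aromatic carbon), in words hydrogen in place of butyl on an aromatic carbon.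

For the measured compounds named here, one measured step bears on this change: a 1.1-fold higher number from compound 2 to compound 3 (0.05 log units; within the scatter), which was butyl in place of fluoro on an aromatic carbon. Going by the values given here, that step stays within the scatter, but it is a single pair, and no measurement yet shows hydrogen on this carbon. Among the compounds with values here, no single-place step connects compound 1 with the others, so its lower number sets no size for this change. The step expected in this assay is a 1.0-fold lower number from compound 3 to compound 4 (0.01 log units; within the scatter), which means no shift beyond the scatter. With so little evidence, the range is kept wide. For compound 4 the estimated value is 750 nM, with an expected range from 300 nM to 2000 nM.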

Compound 4, half-maximal inhibitory concentration: 470 nM
Estimate against measurement, compound 4: 1.6-fold (0.20 log units) above; the range from low to high includes it.
By their numbers in this assay, from the lowest: compound 1; then compounds 4, 2 and 3 (each within the scatter of the next).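

With hydrogen on this aromatic carbon, para to a large group, the series now has an unsubstituted reference for the two earlier substituents. In this assay, for the compounds shown here, the butyl comparison gives (a 1.6-fold lower number from compound 3 to compound 4 (0.21 log units; within the scatter)) and the fluoro comparison gives (a 1.5-fold lower number from compound 2 to compound 4 (0.17 log units; within the scatter)), so neither group separates from hydrogen at this position, and the single earlier pair of butyl and fluoro is now joined by two further comparisons that also stay inside the scatter. Across compounds 2, 3 and 4, this carbon therefore accepts a hydrogen, a small fluoro or a four-carbon butyl chain with no readable shift in the number, and no measured property accounts for that flat result.

Still open, on these data alone, is whether this flat reading holds for a group of another kind on the same carbon, such as an amine, a carboxylic acid or a longer chain than butyl. Also open, as far as these compounds go, is what sets compound 1 apart. Going by these compounds alone, no single-place step links its core to compounds 2, 3 and 4, so the value of compound 1 (170 nM) cannot be assigned to any one change.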